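A few compounds are considered here, and "the series" means these few. Any claim that something is new, unique, unknown or untested is made for them only; others in the source may bear on it.

Working notes, series of compound 1 `COc1ccc(C(=O)Nc2nn(-c3ccccc3)c(=O)c3ccccc23)cc1` and compound 2 `O=C(NCc1ccccc1)Nc1nn(-c2ccccc2)c(=O)c2ccccc12`, both measured in an assay on CHO cells for displacement of a labelled ligand from adenosine receptor A1 (Homo sapiens), tested at 10 uM; on this read-out lower numbers stand for less inhibition and higher numbers for more inhibition at the one concentration tested (going by the name of the read-out). Compound 1 gives 0% in this assay. Compound 2 gives 20% in this assay. Within the data shown here, the one step between them, a number 20 percentage points higher from compound 1 to compound 2 (beyond the scatter), is the only measured change so far. Compound 2 therefore stands highest of the two numbers, with compound 1 as its nearest neighbour at the lower value.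

The next compound, compound 3 `O=C(Nc1nn(-c2ccccc2)c(=O)c2ccccc12)c1ccco1`, is not yet measured in this assay. Compared with compound 2 the change is furan-2-yl in place of benzylamino on a carbonyl carbon.

Among the measured compounds shown here, the only measured step that bears on this is the one from compound 1 to compound 2, where an aryl group on the carbonyl carbon was replaced by benzylamino, a modest rise. Compound 3 reverses this kind of change, putting an aromatic ring back in place of benzylamino. For compound 3 the expected step is a number 15 percentage points lower from compound 2 to compound 3 (beyond the scatter), a drop back toward the number of compound 1, because compound 1 gave 0%. The estimate for compound 3 in this assay is 5%, with a range from 0% to 20%.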

Compound 3, a percentage reported as inhibition, at one concentration (the size of the read-out at that concentration, not a potency): 23%
The estimate for compound 3 lay 18 percentage points below the measured number, and the stated range ends below it.
By their numbers in this assay, from the lowest: compound 1; then compounds 2 and 3 (each within the scatter of the next).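

At the carbonyl carbon, the step of a number 3 percentage points higher from compound 2 to compound 3 (within the scatter) shows that in this assay furan-2-yl does as well as benzylamino, although it is smaller and carries 0 hydrogen-bond donors against 1 for benzylamino. The step of a number 23 percentage points higher from compound 1 to compound 3 (beyond the scatter) then shows that the low number of compound 1 does not belong to every aromatic ring placed directly on this carbonyl carbon: the earlier pair could be read as giving a higher number with benzylamino than with an aryl group, but with furan-2-yl in place, that reading holds only against 4-methoxyphenyl. No measurement available here explains the difference between furan-2-yl and 4-methoxyphenyl.

The compounds shown leave open whether the low number of compound 1 goes with the methoxy group or with the six-membered ring, a question that unsubstituted phenyl and thiophen-2-yl on the same carbonyl carbon would address. They also leave open whether any group at this position can lift the number well past the modest level of compound 2 and compound 3, for example a longer chain or a morpholine.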